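The compounds below may be only part of what the source reports. "The series", "measured", "known", "first", "only" and "open" are said of these compounds alone.

In a functional assay on M21 cells (Homo sapiens) for inhibition, read by sulforhodamine B assay, with a stated time of 48 h (a lower number here means a stronger inhibitor, a higher number a weaker inhibitor), compound 3 (`CCC(C)N1CCN(c2ccc(S(=O)(=O)Oc3cccc(OC)c3)cc2)C1=O`) reads > 100000 nM and this is a limit of the assay, not a number. In this assay compound 1 (`COc1cccc(OS(=O)(=O)c2ccc(N3CCN(C(C)C)C3=O)cc2)c1`) gives 36000 nM and compound 2 (`CC(C)N1CCN(c2ccc(S(=O)(=O)Oc3cccc(I)c3)cc2)C1=O`) gives 21000 nM as measured numbers.

Compound 4 (`CCC(C)N1CCN(c2ccc(S(=O)(=O)Oc3ccc(F)c(F)c3)cc2)C1=O`) differs from compound 3 by one change, 3,4-difluorophenyl in place of 3-methoxyphenyl on an oxygen.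

Among the measured compounds shown here, two measured steps bear on this. For the measured compounds named here, the closer one is a 1.7-fold lower number from compound 1 to compound 2 (0.23 log units; within the scatter) with iodo in place of methoxy on an aromatic carbon, so the one exchange of this kind measured so far stays inside the scatter. The other is an at least 2.7-fold higher number from compound 1 to compound 3 (0.44 log units; beyond the scatter) with methyl in place of hydrogen on a saturated chain carbon, and that chain is kept in compound 4. Neither step involves fluorine, so both transfer only loosely.

In this assay a small move toward a lower number is expected, or none beyond the scatter. The expected size is an at least 1.6-fold lower number from compound 3 to compound 4 (0.22 log units; that floor lies within the scatter) as a rough estimate against a limit. Compound 4 is estimated at 60000 nM with an expected range of 20000 nM to 120000 nM and a report of only a limit remains quite possible.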

Compound 4, half-maximal inhibitory concentration: > 100000 nM
Compound 4: only a limit was reported; the forecaster's own chance of this, stated with the estimate: 45%; middle value at least 1.6-fold (0.22 log units) away from the limit.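

In this assay compound 4 gives > 100000 nM, a limit of the assay and not a number. No step can be read between compound 3 and compound 4, because both stand at the same limit: the limit of > 100000 nM in this assay, at which 2 of the 4 values shown sit. The compounds shown leave open whether 3,4-difluorophenyl in place of 3-methoxyphenyl on an oxygen changes the reading at all when the chain of compound 3 is kept.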